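A few compounds are considered here, and "the series" means these few. Any claim that something is new, unique, unknown or untested is made for them only; others in the source may bear on it.

Measured so far:
compound 1 `c1ccc(CSc2ncnc3[nH]cnc23)cc1` — 28%
compound 2 `Cn1cnc2c(-c3ccccc3)ncnc21` — 8%

Two compounds have been run in an assay on isolated protein for inhibition of Rho-associated protein kinase 1 (Homo sapiens), tested at 30 uM; a higher number here means more inhibition at the concentration tested (going by the name of the read-out), a lower number less inhibition. Compound 1 `c1ccc(CSc2ncnc3[nH]cnc23)cc1` gives 28% in this assay. Compound 2 `Cn1cnc2c(-c3ccccc3)ncnc21` gives 8% in this assay and stands lowest of the two numbers; its nearest neighbour is compound 1, whose number lies higher by a margin beyond the usual scatter. Going by the values given here, no pair of measured compounds differs in a single place, so no measured step is available to lean on.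

The next compound, compound 3 `Cn1cnc2c(-c3ccc(F)cc3)ncnc21`, is derived from compound 2 by one change: fluoro in place of hydrogen on an aromatic carbon. The change adds a single fluorine to the six-membered aromatic ring of carbon only in compound 2 and alters nothing else in the structure.

Among the compounds with values here, with no measured step to go by, and a change of this small size, the step of a number 2 percentage points higher from compound 2 to compound 3 (within the scatter) is expected to be none beyond the scatter, in either direction. Compound 3 is therefore estimated to give 10% in this assay, in the range from 0% to 25%, close to the number found for compound 2.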

Compound 3, a percentage reported as inhibition, at one concentration (the size of the read-out at that concentration, not a potency): 10%
Estimate against measurement, compound 3: no gap at the digits printed; the range from low to high includes it.
By their numbers in this assay, from the lowest: compounds 2 and 3 (each within the scatter of the next); then compound 1.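

Going by these compounds alone, the step of a number 2 percentage points higher from compound 2 to compound 3 (within the scatter) in this assay is the first single-place comparison, and it concerns fluoro in place of hydrogen on an aromatic carbon, para to a large group. At this place on the six-membered aromatic ring of carbon only, adding this one fluorine therefore does not move the read-out beyond the scatter, so compound 2 and compound 3 cannot be told apart in this measurement. Nothing measured here bears on why this step is so small.

On these data alone, a single small replacement says little about how far this place can respond, so it remains open whether an amine, a carboxylic acid or a longer chain here would shift the number beyond the scatter. Also open, as far as these compounds go, are the effect of fluoro on other carbons of that ring and whether any difference between compound 2 and compound 3 would appear at other concentrations, since a single-concentration read-out is not a potency.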